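Bromine's Place on the Amide's Aryl Group: A Small Step Expected

The compounds below may be only part of what the source reports. "The series", "measured", "known", "first", "only" and "open" are said of these compounds alone.

Of the compounds shown here, three with a shared core have been measured so far. In a physicochemical assay, with a stated time of 30 min (on this read-out lower numbers stand for stronger inhibition and higher numbers for weaker inhibition), compound 1 `CCc1ccc(NC(=O)C2Cc3cc(OC)c(OC)cc3C2=O)cc1` gives 76.2 ug/mL, compound 2 `CCOc1ccc(NC(=O)C2Cc3cc(OC)c(OC)cc3C2=O)cc1` gives 48.2 ug/mL, and compound 3 `COc1cc2c(cc1OC)C(=O)C(C(=O)Nc1ccc(Br)cc1)C2` gives 72.1 ug/mL. Compound 3 therefore stands within the usual scatter of both others, so these numbers set none of the three apart.

Compound 4 `COc1cc2c(cc1OC)C(=O)C(C(=O)Nc1cccc(Br)c1)C2` has yet to be measured. It carries 3-bromophenyl in place of 4-bromophenyl on an amide-type nitrogen. For the measured compounds named here, no measured pair shows this kind of change directly. The closest evidence comes from swaps of a single group on an aromatic carbon. These are a 1.6-fold lower number from compound 1 to compound 2 (0.20 log units; within the scatter), a 1.1-fold lower number from compound 1 to compound 3 (0.02 log units; within the scatter) and a 1.5-fold higher number from compound 2 to compound 3 (0.17 log units; within the scatter). All three stay within the scatter, so a step beyond the scatter is not expected, and the data favour no direction. The expected step is a 1.1-fold lower number from compound 3 to compound 4 (0.05 log units; within the scatter), which is too small to be told apart from repeat measurements. Going by the values given here, since no measured compound carries 3-bromophenyl, the range is kept wide. For compound 4 the estimated value in this assay is 65 ug/mL, with an expected range from 35 ug/mL to 120 ug/mL.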

Compound 4, half-maximal inhibitory concentration: 58.9 ug/mL
Compound 4: middle estimate off by 1.1-fold (0.04 log units), on the high side, within the range that was stated.
By their numbers in this assay, from the lowest: compounds 2, 4, 3 and 1 (each within the scatter of the next).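

For the compounds shown here, with the same atoms joined differently, 3-bromophenyl in place of 4-bromophenyl on the amide-type nitrogen gives a 1.2-fold lower number from compound 3 to compound 4 (0.09 log units; within the scatter) in this assay, the first direct look at where the bromine sits on this aryl group rather than at which group is present. A second comparison, 3-bromophenyl in place of 4-ethylphenyl at that same nitrogen, gives a 1.3-fold lower number from compound 1 to compound 4 (0.11 log units; within the scatter), so this new group also cannot be told apart from the 4-ethylphenyl group by this read-out. Across these four compounds, then, neither the choice among ethyl, ethoxy and bromo nor the two bromine placements produces a step that stands clear of repeat measurements, and no separate measurement offers an explanation for this flat picture.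

These compounds leave open whether an amine or a carboxylic acid on the aromatic ring, or a longer chain there, would give a step beyond the scatter. They also leave open whether a plain phenyl group, with no added group at all, would read any differently from the four aryl groups compared here.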